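A few compounds are considered here, and "the series" means these few. Any claim that something is new, unique, unknown or untested is made for them only; others in the source may bear on it.

Of the compounds shown here, three have so far been tested in a functional assay on HepG2 cells (Homo sapiens) for cytotoxicity, read by MTT assay, with a stated time of 48 h; a higher number here means a weaker inhibitor, a lower number a stronger inhibitor. Compound 1 `C/C=C/C=C/C(=O)N[C@H](C(=O)NCCCCCCCCCCCC)[C@@H](C)O` gives in this assay > 400000 nM, which is a limit of the assay rather than a number. Compound 2 `CCCCCCCCCCCCNC(=O)[C@@H](NS(=O)(=O)c1ccc(C)cc1)[C@@H](C)O` gives in this assay 25800 nM. Compound 3 `C/C=C/C=C/C(=O)N[C@H](C(=O)NCCCCCCCCCCCCCC)[C@@H](C)O` gives in this assay > 400000 nM, again a limit of the assay. The change from compound 1 to compound 2 is (4-methylphenyl)sulfonyl in place of (penta-1,3-dien-1-yl)carbonyl on an amine nitrogen and it brings an at least 15-fold lower number from compound 1 to compound 2 (1.19 log units; beyond the scatter). Compound 3 differs from compound 1 by ethyl in place of hydrogen on a saturated chain carbon, ten or more bonds along the chain from an amide-type nitrogen, and that gives a step that the two limits leave unreadable from compound 1 to compound 3 because of the limit of > 400000 nM in this assay, at which 2 of the 3 values shown sit. Compound 4 `CCCCCCCCCCCCCCNC(=O)[C@@H](NS(=O)(=O)c1ccc(C)cc1)[C@@H](C)O` remains to be measured; it differs from compound 3 by (4-methylphenyl)sulfonyl in place of (penta-1,3-dien-1-yl)carbonyl on an amine nitrogen, the same change that separates compound 1 from compound 2. On the core of compound 3 the step is expected to be about as large as the measured one, because the limit of > 400000 nM in this assay, at which 2 of the 3 values shown sit, holds for compound 1 and compound 3 alike. On that basis the estimated step is an at least 13-fold lower number from compound 3 to compound 4 (1.12 log units; beyond the scatter). Compound 4 is expected to give in this assay about 30000 nM, within a range from 8000 nM to 120000 nM.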

Compound 4, half-maximal inhibitory concentration: 10900 nM
Compound 4: middle estimate off by 2.8-fold (0.44 log units), on the high side; low and high end bracket the measured number.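

In this assay, (4-methylphenyl)sulfonyl in place of (penta-1,3-dien-1-yl)carbonyl on the amine nitrogen carries over to the core of compound 3, giving an at least 36-fold lower number from compound 3 to compound 4 (1.56 log units; beyond the scatter), so the change points the same way on both cores: the same change on two cores in this assay, an at least 15-fold lower number (1.19 log units; beyond the scatter) from compound 1 to compound 2 and an at least 36-fold lower number (1.56 log units; beyond the scatter) from compound 3 to compound 4; the limit leaves it open whether they differ Both steps start from a limit of the assay rather than a number, so neither fixes the true size of the change, and the two cannot be ranked: the limit of > 400000 nM in this assay, at which 2 of the 4 values shown sit. With (4-methylphenyl)sulfonyl on the nitrogen, the added ethyl on the chain gives a 2.4-fold lower number from compound 2 to compound 4 (0.37 log units; beyond the scatter), whereas the same chain step with (penta-1,3-dien-1-yl)carbonyl cannot be read.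

The compounds shown leave open whether a shorter or a longer chain would extend this modest step. They also leave open whether the lower number belongs to sulfonyl groups more widely, for instance a methanesulfonyl or an unsubstituted benzenesulfonyl group, or depends on the 4-methylphenyl ring.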